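Moving the ring nitrogen back, with an added methyl

The compounds below may be only part of what the source reports. "The series", "measured", "known", "first", "only" and "open" are said of these compounds alone.

Measured compounds:
Compound 1, `CC(C)(C)c1cc2c(N/N=C\c3ccccn3)ncnc2s1`: in a functional assay on PC-6 cells (Homo sapiens) for antiproliferative activity (a lower number here means a stronger inhibitor, a higher number a weaker inhibitor), compound 1 gives 0.009 ug/mL.
Compound 2, `CC(C)(C)c1cc2c(N/N=C\c3cccnc3)ncnc2s1`: in this assay compound 2 gives 1.45 ug/mL.

For the measured compounds named here, of the two numbers measured, compound 2 has the higher one, so it is the weaker inhibitor; its nearest neighbour is compound 1, and the only step known, a 160-fold higher number from compound 1 to compound 2 (2.21 log units; beyond the scatter), separates them. Compound 3, `Cc1ccc(/C=N\Nc2ncnc3sc(C(C)(C)C)cc23)nc1`, differs from compound 2 by a single exchange: 5-methylpyridin-2-yl in place of pyridin-3-yl on a carbon with a double bond to nitrogen. This exchange restores the arrangement of the ring nitrogen seen in compound 1 and adds a methyl group. Going by the values given here, the one step that bears on it is a 160-fold higher number from compound 1 to compound 2 (2.21 log units; beyond the scatter), read in reverse, which was large and beyond the scatter. A large fall in this assay is therefore expected, a 97-fold lower number from compound 2 to compound 3 (1.99 log units; beyond the scatter), and compound 3 is estimated at 0.015 ug/mL, between 0.003 ug/mL and 0.1 ug/mL.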

Compound 3, half-maximal inhibitory concentration: 0.009 ug/mL
Estimate against measurement, compound 3: 1.7-fold (0.22 log units) above; the range from low to high includes it.
By their numbers in this assay, from the lowest: compounds 1 and 3 (each within the scatter of the next); then compound 2.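

In this assay the large loss seen with pyridin-3-yl is not permanent: a 160-fold lower number from compound 2 to compound 3 (2.21 log units; beyond the scatter) when 5-methylpyridin-2-yl takes its place on the carbon with a double bond to nitrogen. The methyl itself makes no visible difference here, as no change at the digits printed from compound 1 to compound 3 (within the scatter) shows, so this position accepts methyl in place of hydrogen on an aromatic carbon while the pyridin-2-yl form is kept. Nothing measured here explains why the two pyridine forms differ so sharply.

The compounds shown leave open whether an ethyl, a methoxy or an amine on that same aromatic carbon would also leave the number unchanged. Also open, as far as these compounds go, is whether pyridin-4-yl would give a number like that of compound 2, or whether a methyl on its pyridin-3-yl ring would change anything.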